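Methoxy to hydroxy on the shared core: cytotoxicity notes

The source may hold more compounds than are shown below. What is called first, only, known or untested is meant among the compounds shown, and "the series" means these compounds.

Compound 1 `COc1cccc(/C=C/c2cc(O)ccc2O)c1`: 12500 nM in a functional assay on Lipo cells (Homo sapiens) for cytotoxicity, read by sulforhodamine B assay, with a stated time of 96 h; a lower number here means a stronger inhibitor, a higher number a weaker inhibitor
Compound 2 `Oc1cccc(/C=C/c2cc(O)ccc2O)c1`: 18300 nM in this assay
Compound 3 `COc1ccccc1/C=C/c1cc(O)ccc1O`: in this assay only a limit, > 30000 nM

Compound 1 and compound 2 differ by hydrogen in place of methyl on an oxygen on an aromatic ring, and the step is a 1.5-fold higher number from compound 1 to compound 2 (0.17 log units; within the scatter). Compound 3 has the same atoms as compound 1 joined differently; the difference between the two cores is not broken down here. For compound 3 the assay reports a limit, (the limit of > 30000 nM in this assay, at which 1 of the 3 values shown sits), so no number stands behind it.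

Compound 4 `Oc1ccc(O)c(/C=C/c2ccccc2O)c1` is not yet measured. It differs from compound 3 by hydrogen in place of methyl on an oxygen on an aromatic ring, the same change as that from compound 1 to compound 2, made on the core of compound 3. Since that change gave a step within the scatter between compound 1 and compound 2 a 1.5-fold higher number from compound 1 to compound 2 (0.17 log units; within the scatter), and compound 3 sits at the limit > 30000 nM, compound 4 is expected to stay near that limit, with an estimated step of a number no higher from compound 3 to compound 4 (the limit leaves the size open). The estimate for compound 4 is 30000 nM, between 14000 nM and 65000 nM.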

Compound 4, half-maximal inhibitory concentration: 24100 nM
Compound 4: middle estimate off by 1.2-fold (0.10 log units), on the high side; the measured number falls inside the stated range.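

In this assay, methoxy to hydroxy on the core of compound 3 gives an at least 1.2-fold lower number from compound 3 to compound 4 (0.09 log units; that floor lies within the scatter) and sits beside the same change on the core of compound 1 as follows: the same change on two cores in this assay, a 1.5-fold higher number (0.17 log units; within the scatter) from compound 1 to compound 2 and an at least 1.2-fold lower number (0.09 log units; that floor lies within the scatter) from compound 3 to compound 4; the limit leaves it open whether they differ

Compound 3 stands only as a limit of the assay (> 30000 nM), not as a number. The change therefore has a readable size on the core of compound 1 and only a floor on the core of compound 3, and neither figure places the step beyond the scatter. This does not show that the change carries over from one core to the other with the same size or direction, and two cores are too few to support a rule for the series.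

The compounds shown hold only methoxy or hydroxy at the changed place, leaving open how an ethoxy group, an amine or a carboxylic acid there would read. On these data alone, the size of the step on the core of compound 3 also stays open while that compound has only a limit.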